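Two Isomers, One Unmeasured Value

A few compounds are considered here, and "the series" means these few. Any claim that something is new, unique, unknown or untested is made for them only; others in the source may bear on it.

Compound 2 `Cc1cccc(NC(=S)N/N=C/c2ccc3ccccc3n2)c1` stands only at a limit: in a functional assay on HL-60 cells (Homo sapiens) for antiproliferative activity, read by sulforhodamine B assay, with a stated time of 72 h (on this read-out lower numbers stand for stronger inhibition and higher numbers for weaker inhibition), compound 2 gives > 100000 nM, the edge of what the assay can report rather than a number. Compound 1 `COc1ccc(C)cc1NC(=S)N/N=C/c1ccc2ccccc2n1` stands at the same kind of limit, giving > 100000 nM in this assay. The step that the two limits leave unreadable from compound 1 to compound 2 cannot be read because the limit of > 100000 nM in this assay, at which 2 of the 3 values shown sit, swallows both of its ends. Within the data shown here, compound 3 `CN(C)C(=S)N/N=C/c1cnc2ccccc2n1`, built on a different core with a different group on the thiocarbonyl side, gives 90 nM in this assay, but no single-change step joins it to compound 2 or compound 1, so it shows only that strong inhibition is possible within the wider set.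

Compound 4 `Cc1ccccc1NC(=S)N/N=C/c1ccc2ccccc2n1` has not yet been measured. It differs from compound 2 by 2-methylphenyl in place of 3-methylphenyl on an amide-type nitrogen, the same atoms joined differently. Among the measured compounds shown here, no measured step tells what such a swap does, and the one neighbouring step is unreadable. Compound 4 is therefore expected to remain near the limit, so the estimated step is a number no higher from compound 2 to compound 4 (the limit leaves the size open). Compound 4 is estimated at 100000 nM, between 20000 nM and 300000 nM, with a real chance that only a limit is reported.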

Compound 4, half-maximal inhibitory concentration: 73200 nM
Compound 4: middle estimate off by 1.4-fold (0.14 log units), on the high side, within the range that was stated.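

In this assay, among these compounds, the change from 3-methylphenyl to 2-methylphenyl on the amide-type nitrogen brings the first real number to this group of close relatives: compound 4 gives 73200 nM. The change reads as an at least 1.3-fold lower number from compound 2 to compound 4 (0.13 log units; that floor lies within the scatter), and this is only a floor, because the true value of compound 2 stays hidden: the limit of > 100000 nM in this assay, at which 2 of the 4 values shown sit. So rejoining the same atoms differently at this position leaves a measurable value, but the data cannot yet say how large the change really is, or whether it exceeds the scatter.

From the compounds shown here alone, what a carboxylic acid or an amine on this ring would do remains open. So does whether a longer chain in place of the methyl would shift the value further.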